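This account rests on a few compounds, and the source may have more. Where it says the series, first, only, none or still open, it means among the compounds named here.

Compound 1 `CN(C)CCn1cnnc1-c1cc(Oc2ccc(NC(=O)N/N=C/c3ccccc3)cc2F)ccn1`: 2250 nM
Compound 2 `COc1ccc(/C=N/NC(=O)Nc2ccc(Oc3ccnc(-c4nncn4CCN(C)C)c3)c(F)c2)cc1O`: > 100000 nM

Compound 2 sits only at a limit of a functional assay on U-87MG ATCC cells (Homo sapiens) for cytotoxicity, read by MTT assay, with a stated time of 72 h (on this read-out higher numbers stand for weaker inhibition and lower numbers for stronger inhibition), and has no number of its own (the limit of > 100000 nM in this assay, at which 1 of the 2 values shown sits). In this assay, within the data shown here, compound 1 gives 2250 nM, and the single measured step, an at least 44-fold higher number from compound 1 to compound 2 (1.64 log units; beyond the scatter), is large. Compound 3 `CN(C)CCn1cnnc1-c1cc(Oc2ccc(NC(=O)N/N=C/c3cccc(O)c3)cc2F)ccn1` keeps the hydroxy but loses the methoxy: hydrogen in place of methoxy on an aromatic carbon. Among the measured compounds shown here, that undoes part of the only measured step, so compound 3 is expected to land between its two neighbours, as an at least 3.3-fold lower number from compound 2 to compound 3 (0.52 log units; beyond the scatter). Compound 3 is therefore estimated at 30000 nM, from 5000 nM to 100000 nM.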

Compound 3, half-maximal inhibitory concentration: > 100000 nM
Compound 3: no number, only a limit; the forecaster's own chance of this, stated with the estimate: 35%; middle value at least 3.3-fold (0.52 log units) away from the limit.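

The hydroxy alone is enough for the large change in this assay, so the methoxy is not needed for it: an at least 44-fold higher number from compound 1 to compound 3 (1.64 log units; beyond the scatter). Compound 3 gives > 100000 nM, which is a limit and not a number. The step between compound 2 and compound 3 cannot be read, so what the methoxy adds stays unseen, and the read-out has reached its ceiling for both hydroxy compounds: the limit of > 100000 nM in this assay, at which 2 of the 3 values shown sit.

Still open, as far as these compounds go, is whether an amine or a carboxylic acid on this aromatic carbon would keep a value close to that of compound 1.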